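Solubility notes on the shared core: amide variation

A few compounds are considered here, and "the series" means these few. Any claim that something is new, unique, unknown or untested is made for them only; others in the source may bear on it.

Compound 1 `CNS(=O)(=O)c1ccccc1Nc1cc(-c2ccc3ccn(C)c3c2)c2nccnc2c1` gives 2 ug/mL in a physicochemical assay for solubility, read by spectrophotometry, measured as kinetic solubility, at pH 8, tested at 500 uM; a lower number here means a less soluble compound, a higher number a more soluble compound. Compound 2 `CN1CCC(NS(=O)(=O)c2ccccc2Nc2cc(-c3ccc4ccn(C)c4c3)c3nccnc3c2)C1` gives 26 ug/mL. Compound 3 `CN(C)C(=O)c1ccncc1Nc1cc(-c2ccc3ccn(C)c3c2)c2nccnc2c1` gives 175 ug/mL.

Compound 3 stands highest of the three values, above compound 2 and far above compound 1. For the measured compounds named here, the only measured step is a 13-fold higher number from compound 1 to compound 2 (1.11 log units; beyond the scatter), where a larger ring-bearing group replaced a small one on a nitrogen and the number rose strongly. Compound 4 `Cn1ccc2ccc(-c3cc(Nc4cnccc4C(=O)NCC4COCCN4)cc4nccnc34)cc21` differs from compound 3 by ((morpholin-3-yl)methyl)amino in place of dimethylamino on a carbonyl carbon. That precedent points upward, but compound 3 already sits near the top of what this assay can report, so only a small rise or no step beyond the scatter is expected. For compound 4 the estimate is 190 ug/mL, within 90 ug/mL to 240 ug/mL, which is expected to mean a 1.1-fold higher number from compound 3 to compound 4 (0.04 log units; within the scatter).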

Compound 4, solubility: 239 ug/mL
Compound 4: middle estimate off by 1.3-fold (0.10 log units), on the low side; the range from low to high includes it.
By their numbers in this assay, from the lowest: compound 1; then compound 2; then compounds 3 and 4 (each within the scatter of the next).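

In this assay, ((morpholin-3-yl)methyl)amino on the carbonyl carbon gives a 1.4-fold higher number from compound 3 to compound 4 (0.14 log units; within the scatter), so this larger, ring-bearing group leaves the value within the scatter of the dimethylamino amide. The ring-bearing change on the sulfonamide nitrogen gave a 13-fold higher number from compound 1 to compound 2 (1.11 log units; beyond the scatter), and that large step does not recur at this carbonyl carbon. Nothing on hand accounts for the difference between the two changes. Still open, going by these compounds, is how an open-chain amine on a longer chain would read at this carbonyl carbon in this assay. On these data alone, a carboxylic acid in place of the amide is equally open.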